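A Longer Ester-Bearing Chain Replaces Cyclobutyl on the Amine

The source may report more compounds than this note shows. Statements on the series, on what has been measured and on what is new or still open speak of the compounds shown alone.

The series shares a core in which a urea and a primary amide sit on a fused thiophene-piperidine scaffold, and the compounds differ at the urea end and at the ring amine. For the measured compounds named here, compound 1 `NC(=O)c1c(NC(=O)Nc2ccc(Cl)cc2)sc2c1CCN(CC1CCC1)C2` carries a chlorophenyl urea and a cyclobutylmethyl group on the ring amine; in a functional assay (strain AB) with Danio rerio as the target, read by microscopy, with a stated time of 1 h (a higher number here means that more compound is needed for the effect, a lower number that less compound is needed), compound 1 gives 1360 nM, the only numerical value among the three measured compounds. Compound 2 `CCN1CCc2c(sc(NC(=O)NCC3CCCO3)c2C(N)=O)C1` instead bears an ethyl group on the ring amine and an (oxolan-2-yl)methyl urea; in this assay compound 2 reaches only the limit > 25000 nM. Compound 3 `CCN1CCc2c(sc(NC(=O)Nc3ccccc3)c2C(N)=O)C1` keeps the ethyl group but has a phenyl urea; in this assay compound 3 likewise shows only the limit > 25000 nM. The step that the two limits leave unreadable from compound 2 to compound 3 therefore cannot be read, because both values sit at the limit of > 25000 nM in this assay, at which 2 of the 3 values shown sit.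

Compound 4 `CC(C)(C)OC(=O)CCCCN1CCc2c(sc(NC(=O)Nc3ccc(Cl)cc3)c2C(N)=O)C1` is compound 1 with 3-(tert-butoxycarbonyl)propyl in place of cyclobutyl on a saturated chain carbon bound to an amine nitrogen in a ring. Going by the values given here, no measured step changes this position while holding the urea fixed, so no direct precedent exists; the two ethyl-bearing compounds show only that a small amine substituent alongside a different urea gave no readable activity. The chlorophenyl urea of compound 1 is retained in compound 4. Compound 4 is therefore expected to remain measurable but somewhat weaker, with an estimated step of a 2.4-fold higher number from compound 1 to compound 4 (0.37 log units; beyond the scatter). The estimate for compound 4 in this assay is 3200 nM, within a range from 900 nM to 12000 nM.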

Compound 4, half-maximal effective concentration: 710 nM
Estimate against measurement, compound 4: 4.5-fold (0.65 log units) above; measured number below the stated range.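

In this assay, for the compounds shown here, placing 3-(tert-butoxycarbonyl)propyl in place of cyclobutyl on a saturated chain carbon bound to an amine nitrogen in a ring gives a 1.9-fold lower number from compound 1 to compound 4 (0.28 log units; within the scatter), the first readable step at this place, taken with the chlorophenyl urea held fixed. It shows that a chain with no ring, carrying hydrogen-bond acceptors, can stand where the four-membered carbon ring stood and still give a number that cannot be told apart from the earlier one. The earlier compounds could not show anything of this kind, because compound 2 and compound 3 each give a limit and not a number, so the one step between them cannot be read: the limit of > 25000 nM in this assay, at which 2 of the 4 values shown sit.

Going by these compounds, how a carboxylic acid in place of the tert-butyl ester, or a plain pentyl chain on the ring amine, would read in this assay stays open. Also open, on these data alone, is how an ethyl group on the ring amine would read alongside the chlorophenyl urea, a pairing that would connect compound 1 and compound 4 to the ethyl-bearing compound 2 and compound 3.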